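This account rests on a few compounds, and the source may have more. Where it says the series, first, only, none or still open, it means among the compounds named here.

The measured compounds:
Compound 1, `Cc1ccc(C(=O)NNC(=O)c2ccc(NS(=O)(=O)c3cnc(O)nc3O)cc2)cc1`, in a functional assay on OVCAR-3 cells (Homo sapiens) for antiproliferative activity, read by MTT assay, with a stated time of 24 h (on this read-out lower numbers stand for stronger inhibition and higher numbers for weaker inhibition), gives > 20000 nM, which is a limit of the assay and not a number.
Compound 2, `O=C(NNC(=O)c1ccccc1Cl)c1ccc(NS(=O)(=O)c2cnc(O)nc2O)cc1`, in this assay gives 5220 nM.
Compound 3, `Cc1ccc(C(=O)NNC(=O)c2ccccc2NS(=O)(=O)c2cnc(O)nc2O)cc1`, in this assay gives 12900 nM.

Compound 1 and compound 2 differ in one place, (2-chlorophenyl in place of 4-methylphenyl on a carbonyl carbon). The change brought an at least 3.8-fold lower number from compound 1 to compound 2 (0.58 log units; beyond the scatter). Only the lower bound of this step is known because compound 1 sits at the limit of > 20000 nM in this assay, at which 1 of the 3 values shown sits.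

Compound 3 has the same atoms as compound 1, joined differently; the difference between the two cores is not broken down here. Of the two numbers in hand, the value of compound 3 is the higher one, and it stands above compound 2 beyond the usual scatter.

Compound 4, `O=C(NNC(=O)c1ccccc1NS(=O)(=O)c1cnc(O)nc1O)c1ccccc1Cl`, is not yet measured. It differs from compound 3 by 2-chlorophenyl in place of 4-methylphenyl on a carbonyl carbon. The place of the change, on a carbonyl carbon whose other neighbours are an amide-type nitrogen, is the same in both pairs, so this is the same change applied to the core of compound 3 rather than that of compound 1.

Starting from compound 3 at 12900 nM, the expected step is a 3.2-fold lower number from compound 3 to compound 4 (0.51 log units; beyond the scatter), resting on an at least 3.8-fold lower number from compound 1 to compound 2 (0.58 log units; beyond the scatter) as the one earlier instance of the change. Compound 4 is therefore estimated to come in near 4000 nM, between 1500 nM and 12000 nM.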

Compound 4, half-maximal inhibitory concentration: 18200 nM
For compound 4 the middle estimate is 4.6-fold (0.66 log units) below the measured one, outside the stated range (above it).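

In this assay, putting 2-chlorophenyl in place of 4-methylphenyl on the carbonyl carbon did not repeat on the core of compound 3 what it had done on the core of compound 1, for this time the result was a 1.4-fold higher number from compound 3 to compound 4 (0.15 log units; within the scatter). The change therefore cannot be carried from one core to the other in this series with its effect assumed intact, as the two steps differ by more than their scatter: the same change on two cores in this assay, an at least 3.8-fold lower number (0.58 log units; beyond the scatter) from compound 1 to compound 2 and a 1.4-fold higher number (0.15 log units; within the scatter) from compound 3 to compound 4, at least 5.4-fold (0.73 log units) apart, beyond the scatter of two such steps. This rests on a single pair on each core and does not show why the cores part ways, and the gap between the steps is known only as a bound, as compound 1 stands at a limit of the assay and not at a number: the limit of > 20000 nM in this assay, at which 1 of the 4 values shown sits.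

The compounds shown leave open whether the two cores would also part ways with other groups on that carbonyl carbon, such as an unsubstituted phenyl, a 2-methylphenyl or a 4-chlorophenyl. They also leave open which part of the exchange matters on each core, the chlorine that enters or the methyl that leaves, and whether a carboxylic acid or an amine on that ring would follow either core's pattern.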